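The compounds below may be only part of what the source reports. "The series", "measured", "known", "first", "only" and "open" are said of these compounds alone.

Measured in a functional assay (trachea) with Cavia porcellus as the target; a lower number here means a stronger inhibitor, a higher number a weaker inhibitor:
- compound 1 `CCCn1nc(-c2cccnc2)c2ccccc2c1=O`: 3160 nM
- compound 2 `O=C(c1cccs1)n1nc(-c2cccnc2)c2ccccc2c1=O`: 12300 nM
- compound 3 `O=c1c2ccccc2c(-c2cccnc2)nn1CCSc1ncccn1`: 11000 nM

Compound 3 at 11000 nM sits within the scatter of compound 2, and compound 1 has the lowest number of the three.

Next is compound 4 `NCCn1nc(-c2cccnc2)c2ccccc2c1=O`, with the change amino in place of (pyrimidin-2-yl)sulfanyl on a saturated chain carbon, two bonds along the chain from an aromatic nitrogen.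

The most relevant measured step acts at the same carbon: a 3.5-fold higher number from compound 1 to compound 3 (0.54 log units; beyond the scatter), with (pyrimidin-2-yl)sulfanyl in place of methyl. The other step, a 3.9-fold higher number from compound 1 to compound 2 (0.59 log units; beyond the scatter), replaces the whole propyl group and bears on this change only loosely. Compound 4 loses the group that step 1 to 3 brought in, so part of that modest rise may be reversed. Among the measured compounds shown here, no measured compound carries amino, so this remains uncertain.

The expected step is a 1.8-fold lower number from compound 3 to compound 4 (0.26 log units; within the scatter), pointing to a lower number. For compound 4 the estimated value is 6000 nM, with an expected range of 2000 nM to 18000 nM.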

Compound 4, half-maximal inhibitory concentration: > 100000 nM
Compound 4: no number, only a limit; the forecaster's own chance of this, stated with the estimate: 10%; at least 16-fold (1.22 log units) between middle value and limit.
By their numbers in this assay, from the lowest: compound 1; then compounds 3 and 2 (each within the scatter of the next). At a limit, above all of these: compound 4.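

In this assay compound 4 gives only a limit and not a number: the limit of > 100000 nM in this assay, at which 1 of the 4 values shown sits. At the saturated chain carbon, two bonds along the chain from an aromatic nitrogen, amino gives an at least 9.0-fold higher number from compound 3 to compound 4 (0.95 log units; beyond the scatter) and an at least 31-fold higher number from compound 1 to compound 4 (1.50 log units; beyond the scatter), so this place responds far more to amino than the modest earlier steps suggested. On the aromatic nitrogen, 2-aminoethyl gives an at least 8.1-fold higher number from compound 2 to compound 4 (0.91 log units; beyond the scatter), so among these compounds the number does not follow the size of the group, since the single-atom amino stands above the larger (pyrimidin-2-yl)sulfanyl.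

As far as these compounds go, whether the rise belongs to the free amine itself stays open; a dimethylamino group, an acetamide or a hydroxyl at the same carbon would bear on this. From the compounds shown here alone, how far compound 4 lies beyond its limit also stays unknown.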